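The source may report more compounds than this note shows. Statements on the series, on what has been measured and on what is new or still open speak of the compounds shown alone.

Compound 2 `C#CCC[C@H]1O[C@@H](C)[C@H](C)C(Cl)=C1[Si](C)(C)C` is one of two compounds with a number in a functional assay on A2780 cells (Homo sapiens) for antiproliferative activity (a higher number here means a weaker inhibitor of growth, a lower number a stronger inhibitor of growth), where compound 2 gives 21000 nM. The other, compound 1 `C[C@@H]1O[C@H](C2CCCCC2)C([Si](C)(C)C)=C(Cl)[C@H]1C`, gives 19000 nM in this assay; the step of a 1.1-fold higher number from compound 1 to compound 2 (0.04 log units; within the scatter) comes from putting but-3-yn-1-yl in place of cyclohexyl on a saturated ring carbon, and the two numbers lie within the scatter of each other.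

Compound 3 `C=CCC[C@H]1O[C@@H](C)[C@H](C)C(Cl)=C1[Si](C)(C)C` differs from compound 2 by vinyl in place of ethynyl on a saturated chain carbon, two bonds along the chain from a saturated ring carbon, that is, propargyl to allyl, or but-3-yn-1-yl to but-3-en-1-yl. Among the compounds with values here, no measured pair shows this exchange; the only step available, from compound 1 to compound 2, touches the other end of the same chain and stayed within the scatter. On that basis no step beyond the scatter is expected from compound 2 to compound 3, written as no change at the digits printed from compound 2 to compound 3 (within the scatter). Compound 3 is therefore estimated at 21000 nM in this assay, within 9000 nM to 50000 nM.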

Compound 3, concentration for 50% growth inhibition: 17000 nM
For compound 3 the middle estimate is 1.2-fold (0.09 log units) above the measured one, within the range that was stated.
By their numbers in this assay, from the lowest: compounds 3, 1 and 2 (each within the scatter of the next).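

In this assay, within the data shown here, exchanging the ethynyl end of the chain for vinyl gives a 1.2-fold lower number from compound 2 to compound 3 (0.09 log units; within the scatter) and so adds the first reading at this end of the chain, where a triple bond and a double bond cannot be told apart in this assay. Replacing cyclohexyl on the saturated ring carbon with but-3-en-1-yl gives a 1.1-fold lower number from compound 1 to compound 3 (0.05 log units; within the scatter) and so joins the earlier but-3-yn-1-yl exchange as a second chain in place of cyclohexyl that stays within the scatter. No further measurement is available to explain these results.

From the compounds shown here alone, all three compounds carry only carbon and hydrogen in this group, so what an amine, a carboxylic acid or a longer chain would do here remains open. Going by these compounds, the rest of the shared core is the same in all three, so its contribution also remains open.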